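Swapping an Isopropyl for a Hydroxypropyl on the Amide

A few compounds are considered here, and "the series" means these few. Any claim that something is new, unique, unknown or untested is made for them only; others in the source may bear on it.

Compound 1, `CCN(Cc1cc[nH]n1)C(=O)COc1ccc(C)cc1`: "not active" (no number reported)
Compound 2, `Cc1ccc(OCC(=O)N(Cc2cccs2)C(C)C)cc1`: 70 nM
Compound 3, `Cc1ccc(OCC(=O)N(CCCO)Cc2cccs2)cc1`: not yet measured

Of the compounds shown here, two have been tested so far in an assay on HEK293 cells for agonist activity at transient receptor potential cation channel subfamily M member 8 (Homo sapiens), read by fluorescence and calcium flux, with a stated time of 15 min; a lower number here means that less compound is needed, a higher number that more compound is needed for the effect. Compound 1 was reported as "not active" (no number reported), so it gives no number to compare against. Among the measured compounds shown here, that leaves compound 2 as the only compound with a measured value: in this assay compound 2 gives 70 nM, which is therefore the sole point of reference for everything that follows.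

Compound 3 is a close relative of compound 2. The two share the same core; they differ only at the amide-type nitrogen, where the change is 3-hydroxypropyl in place of isopropyl on an amide-type nitrogen. For the measured compounds named here, the new group brings a hydroxyl that the old one lacked, but no measured pair here shows what such a swap does at this position.

Going by the values given here, with only one number available, any forecast must rest on the change itself. The expectation is a modest weakening, so that the step from a 2.9-fold higher number from compound 2 to compound 3 (0.46 log units; beyond the scatter) is estimated to exceed the usual scatter but not by a large margin. For compound 3 in this assay the estimated value is 200 nM, with a likely range from 50 nM to 1000 nM.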

Compound 3, half-maximal effective concentration: 3000 nM
For compound 3 the middle estimate is 15-fold (1.18 log units) below the measured one; the whole stated range lies below it.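

Among the compounds shown here, putting 3-hydroxypropyl in place of isopropyl on the amide-type nitrogen gives, in this assay, a 43-fold higher number from compound 2 to compound 3 (1.63 log units; beyond the scatter), which shows for the first time that the result depends strongly on what this nitrogen carries. For the compounds shown here, until now there was only a single number and no pair to compare, so nothing indicated whether this position would tolerate a change; this pair shows that the swap costs a great deal, since far more compound is needed for the same effect, even though compound 3 still gives a measurable value. Nothing available here accounts for the size of this step.

The swap alters two things together, adding a hydroxyl and replacing a branched group with a straight chain, so compound 2 and compound 3 alone cannot show which of the two carries the step. A plain propyl group would test the chain without the hydroxyl, while a 3-methoxypropyl or 3-aminopropyl group would show how far the outcome depends on the atom at the end of the chain.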